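Aryl hydrazone variation, rat inhibition series

This account rests on a few compounds, and the source may have more. Where it says the series, first, only, none or still open, it means among the compounds named here.

Compound 3 `CC1CC/C(=N\Nc2cccc(Cl)c2)c2ncc(C(=O)O)c(=O)n21` gives 0.6 umol/kg in a functional assay on the whole organism for inhibition, with Rattus norvegicus as the target; a lower number here means that less compound is needed, a higher number that more compound is needed for the effect. Compound 1 `CC1CCC(=NNc2ccccc2)c2ncc(C(=O)O)c(=O)n21` gives 0.6 umol/kg, level with compound 3 at the digits shown and within the scatter. Compound 2 `CC1CC/C(=N\Nc2ccccc2F)c2ncc(C(=O)O)c(=O)n21` gives 5 umol/kg, and the step of an 8.3-fold lower number from compound 2 to compound 3 (0.92 log units; beyond the scatter) is beyond the scatter. Compound 4 `CC1CC/C(=N\Nc2ccccc2O)c2ncc(C(=O)O)c(=O)n21` differs from compound 3 by 2-hydroxyphenyl in place of 3-chlorophenyl on an amine nitrogen. Among the compounds with values here, the one measured step that bears on this, an 8.3-fold lower number from compound 2 to compound 3 (0.92 log units; beyond the scatter), is modest and involves a 2-fluorophenyl giving way to the 3-chlorophenyl of compound 3; the present change brings a 2-hydroxyphenyl in, so a step in the reverse direction is expected. A step of a 3.3-fold higher number from compound 3 to compound 4 (0.52 log units; beyond the scatter) toward a higher number is expected for compound 4, with wide uncertainty since compound 2 is the only reference. Compound 4 is therefore estimated at 2 umol/kg, between 0.6 umol/kg and 8 umol/kg.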

Compound 4, dose for 50% inhibition: 0.26 umol/kg
Compound 4: middle estimate off by 7.7-fold (0.89 log units), on the high side, and the stated range ends above it.
By their numbers in this assay, from the lowest: compound 4; then compounds 1 and 3 (each within the scatter of the next); then compound 2.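

Hydroxy in place of fluoro on an aromatic carbon gives a 19-fold lower number from compound 2 to compound 4 (1.28 log units; beyond the scatter), so the group at this one carbon sets a large part of the range seen so far. With 2-hydroxyphenyl in place of 3-chlorophenyl on the amine nitrogen, the series shows a 2.3-fold lower number from compound 3 to compound 4 (0.36 log units; beyond the scatter), which means the 2-substituted ring is not inherently the poorer choice. Nothing available explains either step.

Still open, from the compounds shown here alone, is whether a methoxy or an amino group on that aromatic carbon would hold the number of compound 4. A 3-hydroxyphenyl group would separate the effect of the hydroxy group from that of its place on the ring.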